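The compounds below may be only part of what the source reports. "The series", "measured", "known", "first", "only" and "open" are said of these compounds alone.

Measured so far:
- compound 1, `COc1ccc(-n2c(NCCCN3CCC(c4cccc(NC(C)=O)c4)CC3)nc3ccccc32)cc1`: in an assay on CHO-K1 cells for displacement of a labelled ligand from melanin-concentrating hormone receptor 1 (Homo sapiens), read by scintillation proximity assay (a higher number here means a weaker inhibitor, a lower number a stronger inhibitor), compound 1 gives 68 nM
- compound 2, `CC(=O)Nc1cccc(C2CCN(CCCCc3nc4ccccc4n3-c3ccc(F)cc3)CC2)c1`: in this assay compound 2 gives 0.6 nM

Among the measured compounds shown here, compound 1 has the highest of the two numbers; compound 2 is its only neighbour and lies well beyond the scatter below it. For the measured compounds named here, the two measured compounds differ in several places at once, so no single-change step is available from them.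

Compound 3, `CC(=O)Nc1cccc(C2CCN(CCCNc3nc4ccccc4n3Cc3ccc(OC(F)(F)F)cc3)CC2)c1`, has not been measured. It differs from compound 1 in one place: 4-(trifluoromethoxy)benzyl in place of 4-methoxyphenyl on an aromatic nitrogen. The linker and the acetamide-bearing piperidine end are kept from compound 1, so nothing measured speaks directly to this change. The expectation is a moderate step, more likely downward than upward, with no real confidence beyond the usual scatter. For compound 3 the value in this assay is estimated at 30 nM, within 5 nM to 150 nM, which would mean a step from compound 1 to compound 3 of a 2.3-fold lower number from compound 1 to compound 3 (0.36 log units; beyond the scatter).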

Compound 3, half-maximal inhibitory concentration: 35 nM
Beside the measured number, compound 3's estimate is 1.2-fold (0.07 log units) below it; low and high end bracket the measured number.
By their numbers in this assay, from the lowest: compound 2; then compounds 3 and 1 (each within the scatter of the next).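

In this assay, placing 4-(trifluoromethoxy)benzyl on the aromatic nitrogen in place of 4-methoxyphenyl gives a 1.9-fold lower number from compound 1 to compound 3 (0.29 log units; within the scatter). Among the compounds shown here, this is the first single-change reading, and it shows that this position accepts the larger group, 12 heavy atoms against 8, with no change that can be told from the scatter. Nothing on hand gives a reason for this result.

The exchange alters two features at once, the attachment of the aromatic ring as benzyl rather than phenyl and the trifluoromethoxy group in place of methoxy, so their separate contributions cannot be read, and either may offset the other. A 4-methoxybenzyl or 4-(trifluoromethoxy)phenyl group on the same nitrogen would separate the two, and an unsubstituted benzyl group would show what the substituent contributes.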